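A few compounds are considered here, and "the series" means these few. Any claim that something is new, unique, unknown or untested is made for them only; others in the source may bear on it.

Measured in a functional assay on MDA-MB-231 cells (Homo sapiens) for cytotoxicity, read by MTT assay, with a stated time of 72 h; on this read-out higher numbers stand for weaker inhibition and lower numbers for stronger inhibition:
- compound 1 `Cc1ccc(NC(=O)CN2CCN(c3nnc(Cc4ccncc4)c4ccccc34)CC2)c(C)c1`: 240 nM
- compound 2 `O=C(CN1CCN(c2nnc(Cc3ccncc3)c3ccccc23)CC1)Nc1ccc(F)c(C(F)(F)F)c1`: 1.9 nM
- compound 3 `Cc1ccc(F)cc1NC(=O)CN1CCN(c2nnc(Cc3ccncc3)c3ccccc23)CC1`: 6.4 nM

At 6.4 nM, compound 3 holds the middle place of the three. Compound 4 `O=C(CN1CCN(c2nnc(Cc3ccncc3)c3ccccc23)CC1)Nc1c(F)cccc1F` differs from it by one group: 2,6-difluorophenyl in place of 5-fluoro-2-methylphenyl on an amide-type nitrogen. All three measured steps change the group on this same amide-type nitrogen. Two are large, a 130-fold lower number from compound 1 to compound 2 (2.10 log units; beyond the scatter) and a 38-fold lower number from compound 1 to compound 3 (1.57 log units; beyond the scatter), and one is modest, a 3.4-fold higher number from compound 2 to compound 3 (0.53 log units; beyond the scatter). Going by the values given here, the group is therefore expected to matter, but no measured compound carries 2,6-difluorophenyl, so the direction is uncertain. A modest rise is the best guess, given that compound 1, the only one without fluorine in this group, sits far higher at 240 nM. The expected step is a 3.1-fold higher number from compound 3 to compound 4 (0.49 log units; beyond the scatter). Compound 4 is estimated at 20 nM, with an expected range of 3 nM to 130 nM.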

Compound 4, half-maximal inhibitory concentration: 1900 nM
Compound 4: the middle estimate sits 95-fold (1.98 log units) below what was measured; the measured number lies above the stated range.
By their numbers in this assay, from the lowest: compound 2; then compound 3; then compound 1; then compound 4.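

Fluorine on this group does not by itself give a low number: a 300-fold higher number from compound 3 to compound 4 (2.47 log units; beyond the scatter) and a 1000-fold higher number from compound 2 to compound 4 (3.00 log units; beyond the scatter) both come with 2,6-difluorophenyl on the amide-type nitrogen. Going by these compounds alone, compound 4 even stands above the only group without fluorine, with a 7.9-fold higher number from compound 1 to compound 4 (0.90 log units; beyond the scatter) as the step, so compound 4 goes against the low numbers of compound 2 and compound 3. Nothing available explains this swap.

Open, as far as these compounds go, is whether a methoxy group or an amine on this phenyl ring, or a pyridine ring in its place, would keep those low numbers.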